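The compounds below may be only part of what the source reports. "The series", "measured", "known", "first", "only" and "open" are said of these compounds alone.

Compound 2, `COc1cc(C(=O)c2sc3ccccc3c2-c2ccc(SC)cc2)cc(OC)c1OC`, gives 3500 nM in a functional assay on HeLa cells (Homo sapiens) for antiproliferative activity, read by MTT assay, with a stated time of 72 h; a higher number here means a weaker inhibitor, a lower number a stronger inhibitor. Among the three measured compounds it holds the second highest number. Compound 1, `COc1cc(C(=O)c2sc3ccccc3c2-c2ccc(F)cc2)cc(OC)c1OC`, gives 3000 nM in this assay, and the step of a 1.2-fold higher number from compound 1 to compound 2 (0.07 log units; within the scatter) shows that the change from fluoro to methylsulfanyl left the number essentially where it was. Compound 3, `COc1ccc(-c2c(C(=O)c3cc(OC)c(OC)c(OC)c3)sc3ccccc23)cc1C`, gives 10000 nM in this assay; here a 2.9-fold higher number from compound 2 to compound 3 (0.46 log units; beyond the scatter) and a 3.3-fold higher number from compound 1 to compound 3 (0.52 log units; beyond the scatter) show a modest weakening when the 4-methoxy-3-methylphenyl group replaces the other aryl groups.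

Compound 4, `COc1ccc(Nc2c(C(=O)c3cc(OC)c(OC)c(OC)c3)sc3ccccc23)cc1`, is not yet measured. It differs from compound 2 in one place: (4-methoxyphenyl)amino in place of 4-(methylsulfanyl)phenyl on an aromatic carbon. All three measured steps concern exchanges of one aryl group for another on this carbon, and the largest of them, a 3.3-fold higher number from compound 1 to compound 3 (0.52 log units; beyond the scatter), was only modest. None of them inserts an amino link between the core and the ring, so the data give no direct guide for that part of the change. Because the aryl swaps at this position moved the number by at most a 2.9-fold higher number from compound 2 to compound 3 (0.46 log units; beyond the scatter), compound 4 is expected to give 5000 nM, between 1500 nM and 20000 nM, a step of a 1.4-fold higher number from compound 2 to compound 4 (0.15 log units; within the scatter) that is estimated with wide uncertainty.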

Compound 4, half-maximal inhibitory concentration: 7700 nM
Compound 4: the middle estimate sits 1.5-fold (0.19 log units) below what was measured; low and high end bracket the measured number.
By their numbers in this assay, from the lowest: compounds 1 and 2 (each within the scatter of the next); then compounds 4 and 3 (each within the scatter of the next).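

In this assay, among these compounds, the first compound with an amino link between this ring carbon and the aromatic ring falls in the same range as the directly attached aryl groups. Its number sits apart from the fluoro and methylsulfanyl compounds (a 2.6-fold higher number from compound 1 to compound 4 (0.41 log units; beyond the scatter); a 2.2-fold higher number from compound 2 to compound 4 (0.34 log units; beyond the scatter)), both modest steps, but stays level with the 4-methoxy-3-methylphenyl compound (a 1.3-fold lower number from compound 3 to compound 4 (0.11 log units; within the scatter)). The position therefore accepts (4-methoxyphenyl)amino, with its added hydrogen-bond donor, without a large shift in either direction, and nothing measured here explains these steps.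

Still open, from the compounds shown here alone, is whether the amino hydrogen matters, as a methylamino, ether oxygen or methylene link would test. Going by these compounds, it is also open whether fluoro or methylsulfanyl on the ring of the amino-linked series would behave as it does on the directly attached ring.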